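The compounds below may be only part of what the source reports. "The series", "measured", "known", "first", "only" and "open" are said of these compounds alone.

Compound 1 `CNC(=O)c1cc(Oc2ccc3nc(Nc4cccc(C(C)(C)C)c4)cnc3c2)ccn1`, compound 2 `CNC(=O)c1cc(Oc2ccc3nc(Nc4cccc(Cl)c4)ncc3c2)ccn1` and compound 3 `CNC(=O)c1cc(Oc2ccc3nc(Nc4cccc(OC(F)(F)F)c4)ncc3c2)ccn1` share one core and differ only in the aryl group on the nitrogen on an aromatic ring. In an ADME assay on Caco-2 cells (Homo sapiens) for permeability, in the apical to basolateral direction (on this read-out lower numbers stand for lower permeability and higher numbers for higher permeability), compound 1 gives < 1 10^-6 cm/s, which is a limit of the assay and not a number. In this assay compound 2 gives < 1 10^-6 cm/s, again a limit. In this assay compound 3 gives < 1 10^-6 cm/s, also a limit, so compound 3 stands at the same limit as the other two and none of the three values shown is a number. Among the compounds with values here, the one step with both ends measured, a step that the two limits leave unreadable from compound 2 to compound 3, is therefore unreadable. What is known is the limit of < 1 10^-6 cm/s in this assay, at which 3 of the 3 values shown sit. Compound 4 `CNC(=O)c1cc(Oc2ccc3nc(Nc4ccc(OC)cc4)ncc3c2)ccn1` differs from compound 3 by 4-methoxyphenyl in place of 3-(trifluoromethoxy)phenyl on a nitrogen on an aromatic ring. Within the data shown here, no measured step covers this change, and the only step available, from compound 2 to compound 3, which alters the group on the aryl ring that enters, gave only two limits. With every value shown sitting at the limit, compound 4 is expected to sit near it as well, and the estimate for compound 4 in this assay is 1 10^-6 cm/s, between 0.3 10^-6 cm/s and 3 10^-6 cm/s. The expected step is a number no lower from compound 3 to compound 4 (the limit leaves the size open), that is, nothing readable beyond the limit.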

Compound 4, apparent permeability: < 1 10^-6 cm/s
Compound 4 was reported as a limit; the forecaster's own chance of this, stated with the estimate: 60%; the middle value lies on the limit itself.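

Compound 4 sits at a limit of this assay, as do compound 2 and compound 3, so neither new step, from compound 3 to compound 4 or from compound 2 to compound 4, can be read. The compounds shown leave open whether changing the aryl group on the nitrogen moves the read-out at all, with only this to go on: the limit of < 1 10^-6 cm/s in this assay, at which 4 of the 4 values shown sit.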